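The source may report more compounds than this note shows. Statements on the series, on what has been measured and on what is new or still open speak of the compounds shown alone.

Compound 2 `Cn1c(Cc2nn(C)c(=O)c3ccccc23)nnc1SCCCCCCCC(=O)Nc1ccc(Cl)cc1` gives 800 nM in an assay on isolated protein (Mus musculus) for inhibition of IL15-IL15 receptor (Homo sapiens), read by resazurin assay, with stated times of 30 min and 2.5 days (a lower number here means a stronger inhibitor, a higher number a weaker inhibitor), the lowest of the two numbers shown. Compound 1 `Cn1c(Cc2nn(C)c(=O)c3ccccc23)nnc1SCCCCCC(=O)Nc1ccc(Cl)cc1Cl` gives 4100 nM in this assay, and the step of a 5.1-fold lower number from compound 1 to compound 2 (0.71 log units; beyond the scatter) is the only measured one. Compound 3 `CCCOc1ccc(NC(=O)CSc2nnc(Cc3nn(C)c(=O)c4ccccc34)n2C)cc1` reaches only a limit of this assay, > 30000 nM, which is the limit of > 30000 nM in this assay, at which 1 of the 3 values shown sits.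

Compound 4 `Cn1c(Cc2nn(C)c(=O)c3ccccc23)nnc1SCCCCCCCC(=O)Nc1ccc(O)cc1O` differs from compound 2 in one place: 2,4-dihydroxyphenyl in place of 4-chlorophenyl on an amide-type nitrogen. Going by the values given here, no measured step touches this kind of change; the single step concerned a chain and a chlorine pattern, so it gives only weak guidance. He therefore expects a modest weakening, a 3.1-fold higher number from compound 2 to compound 4 (0.49 log units; beyond the scatter), with wide uncertainty. His estimate for compound 4 in this assay is 2500 nM, expected to lie between 600 nM and 12000 nM.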

Compound 4, half-maximal inhibitory concentration: 17000 nM
Compound 4: the middle estimate sits 6.8-fold (0.83 log units) below what was measured, outside the stated range (above it).
By their numbers in this assay, from the lowest: compound 2; then compound 1; then compound 4. At a limit, above all of these: compound 3.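

Going by these compounds alone, with the chain held fixed, this is the first read on the aryl group at the amide-type nitrogen, and in this assay the group clearly matters: 2,4-dihydroxyphenyl in place of 4-chlorophenyl gives a 21-fold higher number from compound 2 to compound 4 (1.33 log units; beyond the scatter). The earlier step could not show this, as it changed the chain and the chlorine pattern together. Nothing given here accounts for the loss. The compounds shown leave open whether a single hydroxy group, as in 4-hydroxyphenyl, would cost as much. As far as these compounds go, how 4-aminophenyl or 4-carboxyphenyl on the same nitrogen would compare also remains open.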